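The source may report more compounds than this note shows. Statements on the series, on what has been measured and on what is new or still open speak of the compounds shown alone.

Measured in a functional assay on HL-60 cells (Homo sapiens) for antiproliferative activity, read by MTT assay, with a stated time of 48 h; on this read-out lower numbers stand for stronger inhibition and higher numbers for weaker inhibition:
- Compound 1 (`CC(C)=CCC[C@]1(C)/C=C/[C@@H](OC(=O)C=C(C)C)[C@](C)(O)/C=C/C(=O)/C(CCl)=C\C1`): 160 nM
- Compound 2 (`CSC(=S)OC/C1=C/C[C@](C)(CCC=C(C)C)/C=C/[C@@H](OC(=O)C=C(C)C)[C@](C)(O)/C=C/C1=O`): 180 nM

Within the data shown here, compound 2 lies within the scatter of compound 1, the only other measured compound, so the two values cannot be ranked. Compound 3 (`CCN(CC)C(=O)/C1=C/C[C@](C)(CCC=C(C)C)/C=C/[C@@H](OC(=O)C=C(C)C)[C@](C)(O)/C=C/C1=O`) carries diethylcarbamoyl on a double-bonded ring carbon: a group of 7 heavy atoms (5 carbon, 1 nitrogen, 1 oxygen; no ring) in place of a group of 6 heavy atoms (3 carbon, 1 oxygen, 2 sulfur; no ring), on a double-bonded ring carbon. Among the measured compounds shown here, one measured step bears on this change, a 1.1-fold higher number from compound 1 to compound 2 (0.05 log units; within the scatter), and it lies within the scatter. That step sits on a saturated chain carbon bound to a double-bonded ring carbon and does not involve diethylcarbamoyl, so it offers only weak guidance. A modest step toward a higher number is expected in this assay, although the data settle neither its size nor its direction. The estimated step is a 1.7-fold higher number from compound 2 to compound 3 (0.22 log units; within the scatter). Compound 3 is estimated at 300 nM, with an expected range from 90 nM to 1000 nM.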

Compound 3, half-maximal inhibitory concentration: 9080 nM
Compound 3: the middle estimate sits 30-fold (1.48 log units) below what was measured, and the stated range ends below it.
By their numbers in this assay, from the lowest: compounds 1 and 2 (each within the scatter of the next); then compound 3.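

In this assay, this double-bonded ring carbon proves sensitive to what it carries: diethylcarbamoyl gives a 50-fold higher number from compound 2 to compound 3 (1.70 log units; beyond the scatter) and a 57-fold higher number from compound 1 to compound 3 (1.75 log units; beyond the scatter) in this series, whereas a 1.1-fold higher number from compound 1 to compound 2 (0.05 log units; within the scatter) stays within the scatter. The two groups compared in that earlier step both reach the ring through a saturated chain carbon, so tolerance of that exchange does not extend to a carbonyl group placed directly on the ring carbon. No measurement shown explains the large rise in the number.

Still open, going by these compounds, is whether the rise follows from removing the saturated chain carbon or from the diethylamide itself. A diethylaminomethyl group or a primary amide at this ring carbon would help separate the two, and a carboxylic acid there would test a carbonyl group without the diethylamino part.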